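From 2-chlorophenyl to 4-nitrophenyl in compound 3

A few compounds are considered here, and "the series" means these few. Any claim that something is new, unique, unknown or untested is made for them only; others in the source may bear on it.

In a functional assay on U-937 cells (Homo sapiens) for antiproliferative activity, read by MTT assay, with a stated time of 72 h (on this read-out lower numbers stand for stronger inhibition and higher numbers for weaker inhibition), compound 2 (`Nc1ccccc1NC(=O)CCCCCCc1nc(-c2ccccc2Cl)no1`) gives 6910 nM and compound 1 (`Nc1ccccc1NC(=O)CCCCCCc1nc(-c2ccc(Cl)cc2)no1`) gives 4360 nM and these two values lie within the scatter of each other. Compound 3 (`Nc1ccccc1NC(=O)CCCCCCc1nc(-c2ccc([N+](=O)[O-])cc2)no1`) carries 4-nitrophenyl in place of 2-chlorophenyl on an aromatic carbon. Among the measured compounds shown here, the one measured step bearing on this (a 1.6-fold higher number from compound 1 to compound 2 (0.20 log units; within the scatter)) exchanged 4-chlorophenyl for 2-chlorophenyl and stayed within the scatter, and no compound with 4-nitrophenyl has been measured. No step beyond the scatter is therefore expected in this assay and the estimated step is small (a 1.4-fold lower number from compound 2 to compound 3 (0.14 log units; within the scatter)). Compound 3 is expected at 5000 nM (estimated range 2000 nM to 12000 nM).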

Compound 3, half-maximal inhibitory concentration: 10300 nM
Compound 3: the middle estimate sits 2.1-fold (0.31 log units) below what was measured, and the stated range covers the measured number.
By their numbers in this assay, from the lowest: compounds 1, 2 and 3 (each within the scatter of the next, the first and the last beyond it).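

In this assay, exchanging the group on this aromatic carbon now gives a step beyond the scatter, though a modest one, with nitro in place of chloro on the phenyl ring (a 2.4-fold higher number from compound 1 to compound 3 (0.37 log units; beyond the scatter)). The change from 2-chlorophenyl to 4-nitrophenyl stays within the scatter (a 1.5-fold higher number from compound 2 to compound 3 (0.17 log units; within the scatter)), so only the comparison with compound 1 separates these groups. No measurement available here explains the step. The compounds shown leave open how an amine or a carboxylic acid on this phenyl ring would read. They also leave open whether an unsubstituted phenyl would differ from compound 1 or compound 3.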